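This account rests on a few compounds, and the source may have more. Where it says the series, first, only, none or still open, it means among the compounds named here.

Working notes on the shared core. Compound 3 `Cc1nn(C)c(-n2ccc3ccccc32)c1/C=N/OCc1ccc(C(=O)OC(C)(C)C)cc1` stands alongside compound 1 `Cc1nn(C)c(-n2cccc2)c1/C=N/OCc1ccc(C(=O)OC(C)(C)C)cc1` and compound 2 `Cc1nn(C)c(-n2cccn2)c1/C=N/OCc1ccc(C(=O)OC(C)(C)C)cc1`. In a functional assay on A549 cells (Homo sapiens) for cytotoxicity (on this read-out higher numbers stand for weaker inhibition and lower numbers for stronger inhibition), compound 3 gives 0.43 ug/mL, the lowest of the three numbers. Compound 1 gives 1.64 ug/mL and compound 2 gives 2.49 ug/mL. The steps of a 3.8-fold lower number from compound 1 to compound 3 (0.58 log units; beyond the scatter) and a 5.8-fold lower number from compound 2 to compound 3 (0.76 log units; beyond the scatter) both lie beyond the scatter, so compound 3 is the strongest inhibitor measured here, whereas a 1.5-fold higher number from compound 1 to compound 2 (0.18 log units; within the scatter) stays within the scatter.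

The next step leads to compound 4 `Cc1nn(C)c(N(C)C)c1/C=N/OCc1ccc(C(=O)OC(C)(C)C)cc1`, not yet measured. The change is dimethylamino in place of 1H-indol-1-yl on an aromatic carbon. The measured steps that bear on it are those at the same aromatic carbon, where 1H-indol-1-yl replaced 1H-pyrrol-1-yl or 1H-pyrazol-1-yl and gave a 3.8-fold lower number from compound 1 to compound 3 (0.58 log units; beyond the scatter) and a 5.8-fold lower number from compound 2 to compound 3 (0.76 log units; beyond the scatter). For the measured compounds named here, no measured step covers a dimethylamino group at this position. Since both gains are tied to 1H-indol-1-yl, removing it is expected to give back the advantage, and a modest step toward a higher number in this assay is expected for compound 4, about a 5.8-fold higher number from compound 3 to compound 4 (0.76 log units; beyond the scatter). Compound 4 is estimated at 2.5 ug/mL, with a range from 1 ug/mL to 6 ug/mL.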

Compound 4, half-maximal inhibitory concentration: 2.76 ug/mL
Compound 4: the middle estimate sits 1.1-fold (0.04 log units) below what was measured; the measured number falls inside the stated range.
By their numbers in this assay, from the lowest: compound 3; then compounds 1, 2 and 4 (each within the scatter of the next).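

In this assay, the open-chain dimethylamino group shows that this aromatic carbon need not carry a ring to match the pyrrole and pyrazole compounds, since a 1.1-fold higher number from compound 2 to compound 4 (0.04 log units; within the scatter) and a 1.7-fold higher number from compound 1 to compound 4 (0.23 log units; within the scatter) both stay within the scatter. The step of a 6.4-fold higher number from compound 3 to compound 4 (0.81 log units; beyond the scatter) lies beyond the scatter, so compound 3 remains the strongest inhibitor of the four, and among these substituents only 1H-indol-1-yl, the one group here with a six-membered aromatic ring, stands apart from the rest. No supporting data are available on why this group stands apart.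

The compounds shown do not separate the contribution of the six-membered aromatic ring from the larger number of heavy atoms in 1H-indol-1-yl, and a non-aromatic ring amine such as piperidin-1-yl or a larger open-chain amine such as dibenzylamino on the same aromatic carbon would bear on that question. On these data alone, all four compounds also keep the tert-butyl ester, so it remains open whether the order seen at this position would hold with a free carboxylic acid or an amide in its place.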